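The source may hold more compounds than are shown below. What is called first, only, known or untested is meant among the compounds shown, and "the series" means these compounds.

Compound 3 `Cc1cc(C)cc(S(=O)(=O)c2c(C(=O)NC(C)c3cc(F)cc(F)c3)[nH]c3ccc(Cl)cc23)c1` and compound 4 `Cc1cc(C)cc(S(=O)(=O)c2c(C(=O)NC(C)C(=O)NCc3ccco3)[nH]c3ccc(Cl)cc23)c1` share one core and differ at a single point. In an ADME assay on MT4 cells (Homo sapiens) for cytotoxicity, read by MTT assay (a lower number here means that less compound is tolerated, a higher number that more compound is tolerated), compound 3 reaches only a limit, > 49700 nM, and so gives no number. Compound 1 `Cc1cc(C)cc(S(=O)(=O)c2c(C(=O)NCc3cccc(N)c3)[nH]c3ccc(Cl)cc23)c1` likewise reaches only a limit in this assay, > 53400 nM. Compound 2 `Cc1cc(C)cc(S(=O)(=O)c2c(C(=O)NC(C)C(=O)NC(C)c3ccccc3F)[nH]c3ccc(Cl)cc23)c1` gives a number in this assay, 15200 nM.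

The change to compound 4 is ((furan-2-yl)methyl)carbamoyl in place of 3,5-difluorophenyl on a saturated chain carbon bound to an amide-type nitrogen and a saturated chain carbon. The measured step that bears on it runs the other way: an at least 3.2-fold higher number from compound 2 to compound 3 (0.51 log units; beyond the scatter), where a carbamoyl-bearing side chain gave way to a plain aryl ring and the number rose past a limit. Compound 4 brings a carbamoyl back, so a lower number than that of compound 3 is expected, though the step from compound 1 to compound 3 stays unreadable between two limits.

The expected step is an at least 1.9-fold lower number from compound 3 to compound 4 (0.29 log units; that floor lies within the scatter), putting compound 4 at an estimated 25000 nM, between 8000 nM and 60000 nM.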

Compound 4, half-maximal cytotoxic concentration: 24200 nM
The estimate for compound 4 lay 1.0-fold (0.01 log units) above the measured number, within the range that was stated.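

Putting ((furan-2-yl)methyl)carbamoyl in place of 3,5-difluorophenyl on this saturated chain carbon gives, in this assay, an at least 2.0-fold lower number from compound 3 to compound 4 (0.31 log units; beyond the scatter). Within the carbamoyl side chain, the end group has shown no clear effect so far: (furan-2-yl)methyl in place of 1-(2-fluorophenyl)ethyl on the amide-type nitrogen gives a 1.6-fold higher number from compound 2 to compound 4 (0.20 log units; within the scatter). Replacing the 3-aminobenzyl group on the amide-type nitrogen with 1-(((furan-2-yl)methyl)carbamoyl)ethyl gives an at least 2.2-fold lower number from compound 1 to compound 4 (0.34 log units; beyond the scatter), so compound 4 joins compound 2 in giving a number rather than a limit.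

As far as these compounds go, compound 3 reaches only a limit, so the full size of its step remains open, and the same caution applies to the step from compound 1: the limit of > 49700 nM in this assay, at which 1 of the 4 values shown sits. Also open is how a carboxylic acid or an amine at the far end of the carbamoyl side chain, or a longer chain there, would read in this assay.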